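The compounds below may be only part of what the source reports. "The series", "measured", "known", "first", "only" and "open" are said of these compounds alone.

Compound 3 `COc1cc2cc(Oc3ccc(NC(=O)Nc4cccc(C(F)(F)F)c4)cc3)c(C)nc2cc1OC` stands at the strongest end of the three numbers in a functional assay on PC-3 cells (Homo sapiens) for inhibition, read by sulforhodamine B assay, with a stated time of 48 h, tested at 10 uM (on this read-out lower numbers stand for a stronger effect and higher numbers for a weaker effect at the one concentration tested), where compound 3 gives 0.08%. Compound 1 `COc1cc2cc(Oc3ccc(NC(=O)Nc4ccc(C)cc4)cc3)c(C)nc2cc1OC` gives 94.5% and compound 2 `COc1cc2cc(Oc3ccc(NC(=O)Nc4ccc(C(F)(F)F)cc4)cc3)c(C)nc2cc1OC` gives 48.3%. All steps between them are large: a number 46.2 percentage points lower from compound 1 to compound 2 (beyond the scatter), a number 94.4 percentage points lower from compound 1 to compound 3 (beyond the scatter) and a number 48.2 percentage points lower from compound 2 to compound 3 (beyond the scatter). Compound 4 `COc1cc2cc(Oc3ccc(NC(=O)Nc4ccc(Cl)c(Cl)c4)cc3)c(C)nc2cc1OC` differs from compound 3 by 3,4-dichlorophenyl in place of 3-(trifluoromethyl)phenyl on an amide-type nitrogen. Going by the values given here, no measured step exchanges a trifluoromethyl for chlorine, so none bears directly on this change; the nearest guide is a number 48.2 percentage points lower from compound 2 to compound 3 (beyond the scatter), which shows that the phenyl pattern on this nitrogen can shift the read-out strongly. Because compound 3 already gives 0.08%, the number for compound 4 is expected to remain low, with a step of about a number 14.9 percentage points higher from compound 3 to compound 4 (beyond the scatter). Compound 4 is estimated at 15%, range 0% to 55%.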

Compound 4, a percentage reported as activity, at one concentration (the size of the read-out at that concentration, not a potency): 4.12%
The estimate for compound 4 lay 10.9 percentage points above the measured number; the range from low to high includes it.
By their numbers in this assay, from the lowest: compounds 3 and 4 (each within the scatter of the next); then compound 2; then compound 1.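

In this assay, 3,4-dichlorophenyl on the amide-type nitrogen stands level with 3-(trifluoromethyl)phenyl, with a number 4 percentage points higher from compound 3 to compound 4 (within the scatter), so among these compounds a low number at this position does not depend on trifluoromethyl. The gaps to the other two groups stay large, with a number 44.2 percentage points lower from compound 2 to compound 4 (beyond the scatter) and a number 90.4 percentage points lower from compound 1 to compound 4 (beyond the scatter). No measurement here addresses the cause of these steps.

Open, as far as these compounds go, is whether 3-chlorophenyl alone, 3-aminophenyl or 3-carboxyphenyl on this nitrogen would also give a low number. A single concentration also leaves the potency of compound 3 and compound 4 unresolved.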